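Swapping Methoxy for Chloro on the Pendant Phenyl

The source may report more compounds than this note shows. Statements on the series, on what has been measured and on what is new or still open speak of the compounds shown alone.

Compound 1 `COc1ccc(-c2nn(-c3ccccc3)cc2C(=O)NOCc2ccccc2Cl)cc1` gives 3730 nM in a functional assay on MCF7 cells (Homo sapiens) for antiproliferative activity, read by MTT assay, with a stated time of 48 h, in the presence of a further agent that is not named here; a higher number here means a weaker inhibitor of growth, a lower number a stronger inhibitor of growth.
Compound 2 `COc1ccc(-c2nn(-c3ccccc3)cc2C(=O)NOCc2ccc(Cl)cc2Cl)cc1` gives 2570 nM in this assay.

Going by the values given here, compound 2 holds the smaller of the two numbers, but the only measured step, a 1.5-fold lower number from compound 1 to compound 2 (0.16 log units; within the scatter), lies within the scatter, so the two compounds cannot be ranked. Compound 3 `O=C(NOCc1ccc(Cl)cc1Cl)c1cn(-c2ccccc2)nc1-c1ccc(Cl)cc1` differs from compound 2 by chloro in place of methoxy on an aromatic carbon. No measured step touches this ring or this exchange, so nothing shown speaks for a shift beyond the scatter in this assay. Compound 3 is therefore expected to sit near compound 2, with a 1.0-fold lower number from compound 2 to compound 3 (0.01 log units; within the scatter) anticipated, and is estimated at 2500 nM, ranging from 900 nM to 7000 nM.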

Compound 3, concentration for 50% growth inhibition: 16200 nM
Estimate against measurement, compound 3: 6.5-fold (0.81 log units) below; the whole stated range lies below it.
By their numbers in this assay, from the lowest: compounds 2 and 1 (each within the scatter of the next); then compound 3.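

Going by these compounds alone, the ring carrying the methoxy is the first place where a change moves the number beyond the scatter: in this assay, going from 4-methoxyphenyl to 4-chlorophenyl gives a 6.3-fold higher number from compound 2 to compound 3 (0.80 log units; beyond the scatter). The earlier chloro change, a 1.5-fold lower number from compound 1 to compound 2 (0.16 log units; within the scatter), stayed within the scatter, so growth inhibition here responds to what this position carries. No supporting measurement bears on why this exchange matters.

On these data alone, it remains open how a hydroxyl, an amine or a longer chain such as ethoxy would fare at this place. As far as these compounds go, whether the same exchange on compound 1 would have a similar effect also remains open.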